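The compounds below may be only part of what the source reports. "The series", "measured", "known", "first", "only" and "open" are said of these compounds alone.

For the measured compounds named here, in a functional assay (Nicotiana tabacum) (a higher number here means a weaker inhibitor, a lower number a stronger inhibitor), compound 1 `CNc1nc(SC)nc2ncccc12` gives 2920 nM and compound 2 `CCCNc1nc(SC)nc2ncccc12` gives 270 nM, the lower of the two numbers measured so far. Going by the values given here, the two compounds share one core, and the only measured step between them is large and beyond the scatter: an 11-fold lower number from compound 1 to compound 2 (1.03 log units; beyond the scatter). That step adds ethyl to a saturated chain. Compound 3 `CCCCNc1nc(SC)nc2ncccc12` lengthens the same chain further, taking propyl to butyl: methyl in place of hydrogen on a saturated chain carbon, three bonds along the chain from a nitrogen on an aromatic ring. This is methyl in place of hydrogen on a saturated chain carbon, three bonds along the chain from a nitrogen on an aromatic ring. Among the compounds with values here, the earlier step is the only guide, and one step cannot show whether the trend continues. The new change is also smaller, adding methyl where the earlier one added ethyl. A modest move toward a lower number in this assay is therefore expected, one that may stay within the scatter. The expected step is a 1.8-fold lower number from compound 2 to compound 3 (0.26 log units; within the scatter). For compound 3 the estimated value is 150 nM, with an expected range of 55 nM to 420 nM.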

Compound 3, half-maximal inhibitory concentration: 270 nM
The estimate for compound 3 lay 1.8-fold (0.26 log units) below the measured number; the range from low to high includes it.
By their numbers in this assay, from the lowest: compounds 2 and 3 (each within the scatter of the next); then compound 1.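

In this assay, methyl in place of hydrogen on a saturated chain carbon, three bonds along the chain from a nitrogen on an aromatic ring, gives no change at the digits printed from compound 2 to compound 3 (within the scatter), so taking propyl to butyl does not continue the large step seen between the first two compounds. Compound 3 retains the full difference from the chain of compound 1, with an 11-fold lower number from compound 1 to compound 3 (1.03 log units; beyond the scatter), and the three compounds therefore show one large step followed by a flat one, not a steady trend with chain length. Nothing available explains why the numbers level off across this change.

The compounds shown leave open whether a longer chain such as pentyl or hexyl would stay level with compounds 2 and 3 or depart from them, and whether an ethyl chain would already account for the large step from compound 1. They also leave open how a branched chain such as isobutyl, or a butyl chain ending in an amine or a carboxylic acid, would read in this assay.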